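The source may hold more compounds than are shown below. What is called first, only, known or untested is meant among the compounds shown, and "the series" means these compounds.

Measured compounds:
- compound 1, `CCCCOCCn1c(N2CCCN(C)CC2)nc2ccccc21`: in a functional assay on ileum for inhibition of histamine H1 receptor (Cavia porcellus) (on this read-out lower numbers stand for stronger inhibition and higher numbers for weaker inhibition), compound 1 gives 10 nM
- compound 2, `CCCCCCCn1c(N2CCN(C)CC2)nc2ccccc21`: in this assay compound 2 gives 150 nM

Going by the values given here, compound 2 stands at the highest of the two numbers measured so far in this assay; compound 1 sits at a lower number, and that gap is beyond the scatter. Among the compounds with values here, no pair of measured compounds differs in only a single place, so no single-point step can be read directly from the numbers.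

Compound 3, `CN1CCN(c2nc3ccccc3n2CCO)CC1`, is the compound awaiting measurement in this assay. It differs from compound 2 by the change (hydroxy in place of pentyl on a saturated chain carbon, two bonds along the chain from an aromatic nitrogen). The shared core and the methyl-bearing saturated ring of compound 2 are kept.

Within the data shown here, nothing among the measured compounds isolates the effect of shortening the chain on the aromatic nitrogen to a hydroxy-bearing two-carbon unit. On the expectation that the step from compound 2 to compound 3 in this assay is a 2.0-fold higher number from compound 2 to compound 3 (0.30 log units; within the scatter), the number for compound 3 is estimated at 300 nM, within a range from 60 nM to 1500 nM.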

Compound 3, half-maximal inhibitory concentration: 410 nM
The estimate for compound 3 lay 1.4-fold (0.14 log units) below the measured number; the range from low to high includes it.
By their numbers in this assay, from the lowest: compound 1; then compound 2; then compound 3.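

In this assay, going by these compounds alone, the series now has its first step at a single place: hydroxy in place of pentyl on a saturated chain carbon, two bonds along the chain from an aromatic nitrogen, gives a 2.7-fold higher number from compound 2 to compound 3 (0.44 log units; beyond the scatter) and is the only direct reading so far at this position. The change from heptyl to 2-hydroxyethyl therefore costs only a modest amount of inhibition, and compound 3 still reads 410 nM without the long all-carbon chain of compound 2. No measurement available here bears on what lies behind this step.

The step combines removal of chain carbons with arrival of a hydroxy group, so their separate contributions remain unresolved; a plain ethyl chain on the same aromatic nitrogen would separate them, and a 2-aminoethyl or carboxymethyl group would widen the range of end groups tested at this position. Within the data shown here, compound 1 differs from the other compounds in more than one place, so no step to it can be read, and the separate contributions of its chain and its saturated ring remain open.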